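The compounds below may be only part of what the source reports. "The series", "measured", "known", "first", "only" and "open" are said of these compounds alone.

In an assay on isolated protein for inhibition of Aromatase (Homo sapiens), read by fluorescence, with a stated time of 10 min (a lower number here means a stronger inhibitor, a higher number a weaker inhibitor), compound 1 `COc1cc2c(cc1OC)CN(S(=O)(=O)c1cccc(-n3cc(COc4ccc5ccc(=O)oc5c4)nn3)c1)CC2` gives 200 nM. Among the measured compounds shown here, compound 2 `COc1cc2c(cc1OC)CN(S(=O)(=O)c1ccc(-n3cc(COc4ccc([N+](=O)[O-])cc4)nn3)cc1)CC2` gives 12500 nM in this assay, the higher of the two numbers so far, and its gap to compound 1 lies beyond the scatter. The two measured compounds differ in more than one place, so only their two values can be set side by side. Compound 3 `COc1cc2c(cc1OC)CN(S(=O)(=O)c1ccc(-n3cc(COc4ccccc4C(C)=O)nn3)cc1)CC2` is not yet measured. It differs from compound 2 by 2-acetylphenyl in place of 4-nitrophenyl on an oxygen on a saturated carbon. For the measured compounds named here, no measured pair bears on this change, so the expected step from compound 2 to compound 3 is a 1.4-fold lower number from compound 2 to compound 3 (0.14 log units; within the scatter), none beyond the scatter. For compound 3 the estimate in this assay is 9000 nM, with a range of 2500 nM to 30000 nM.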

Compound 3, half-maximal inhibitory concentration: 12500 nM
The estimate for compound 3 lay 1.4-fold (0.14 log units) below the measured number, within the range that was stated.
By their numbers in this assay, from the lowest: compound 1; then compounds 2 and 3 (each within the scatter of the next).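

In this assay, 2-acetylphenyl in place of 4-nitrophenyl on an oxygen on a saturated carbon gives no change at the digits printed from compound 2 to compound 3 (within the scatter). Among the compounds shown here, this is the first single-place comparison at this position, and the read-out does not separate these two groups. Nothing measured bears on why the two compounds read alike.

From the compounds shown here alone, whether an amine or a carboxylic acid in place of these groups would move the number remains open. Going by these compounds, compound 1 differs from compound 2 in more than one place, so the source of its lower number also remains open.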